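The source may report more compounds than this note shows. Statements on the series, on what has been measured and on what is new or still open speak of the compounds shown alone.

Measured compounds:
Compound 1, `CC1(C)Cc2c(Oc3ccccc3)cc(C(=O)O)cc2O1`: in a functional assay on the whole organism with Homo sapiens as the target, read by hemolysis (on this read-out lower numbers stand for stronger inhibition and higher numbers for weaker inhibition), compound 1 reaches only the limit of > 1050000 nM.
Compound 2, `COc1cc(-c2nn[nH]n2)cc2c1CC(C)(C)O2`: in this assay compound 2 gives 245000 nM.

Within the data shown here, compound 2 holds the only actual number in this assay. Among the measured compounds shown here, the other result, (the limit of > 1050000 nM in this assay, at which 1 of the 2 values shown sits), is a limit rather than a number, so no measured step between two compounds exists here, and nothing shows how much the read-out moves when one part of the shared core is swapped for another.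

Compound 3, `CC1(C)Cc2c(Oc3ccccc3)cc(-c3nn[nH]n3)cc2O1`, has not yet been measured. It differs from compound 2 by phenyl in place of methyl on an oxygen on an aromatic ring, that is, methoxy becomes phenoxy while the tetrazole of compound 2 is kept. Compound 1 already carries the phenoxy, though with a carboxylic acid in place of the tetrazole, and its result is a limit.

For the measured compounds named here, with no measured step to rest on, the expected step from compound 2 to compound 3 in this assay is a 1.2-fold higher number from compound 2 to compound 3 (0.09 log units; within the scatter), a change no larger than the usual scatter, with a fair chance that the assay again reports only a limit. Compound 3 is therefore estimated at 300000 nM, with a range from 80000 nM to 1050000 nM.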

Compound 3, half-maximal inhibitory concentration: 195000 nM
Beside the measured number, compound 3's estimate is 1.5-fold (0.19 log units) above it; the range from low to high includes it.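

On an oxygen on an aromatic ring, replacing methyl with phenyl, that is, methoxy with phenoxy, brings in a whole six-membered aromatic ring, yet in this assay this change gives a 1.3-fold lower number from compound 2 to compound 3 (0.10 log units; within the scatter), so the larger group leaves the read-out without a real change at this position. With the phenoxy held in place, the change of 2H-tetrazol-5-yl in place of carboxy on an aromatic carbon gives an at least 5.3-fold lower number from compound 1 to compound 3 (0.73 log units; beyond the scatter), the first step in this series that lies beyond the scatter, so among the changes shown, only the one on this aromatic carbon moves the read-out beyond the scatter. That step rests on compound 1, whose result is a limit rather than a number: the limit of > 1050000 nM in this assay, at which 1 of the 3 values shown sits.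

An ethyl or a benzyl on the same oxygen would show whether the read-out also stays put for groups other than methyl and phenyl. As far as these compounds go, it also remains open whether an amide or a sulfonamide on the aromatic carbon that carries the tetrazole would give a number like that of compound 3 195000 nM.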